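The compounds below may be only part of what the source reports. "The series", "measured", "known", "first", "only" and "open" are said of these compounds alone.

Compound 1 `COCOc1cc(/C=C/C(=O)OCC(=O)NN2CCOCC2)ccc1OCc1ccccc1`, compound 2 `COc1ccc(NC(=O)COC(=O)/C=C/c2cc(OC)c(OCc3ccc(Cl)c(Cl)c3)c(OC)c2)cc1` and compound 3 `CCOc1ccc(COc2c(OC)cc(/C=C/C(=O)N3CCN(Cc4ccc(Cl)c(Cl)c4)CC3)cc2OC)cc1` share a common core and were all tested in a functional assay on CNE cells (Homo sapiens) for cytotoxicity, read by MTT assay, with a stated time of 72 h; on this read-out lower numbers stand for stronger inhibition and higher numbers for weaker inhibition. In this assay compound 1 returned only a limit of the assay, > 200000 nM. In this assay compound 2 also returned only a limit, > 200000 nM. In this assay compound 3 likewise returned only a limit, > 200000 nM. Compound 2 therefore stands where all three readings sit, at the limit of > 200000 nM in this assay, at which 3 of the 3 values shown sit, so no number separates it from the other two compounds, and the readings say only that none of the three reached half-maximal inhibition within the tested range.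

Compound 4 `COc1ccc(NC(=O)COC(=O)/C=C/c2cc(OC)c(OCc3ccccc3)c(OC)c2)cc1` has not yet been measured. It differs from compound 2 in one place: phenyl in place of 3,4-dichlorophenyl on a saturated chain carbon bound to an oxygen on an aromatic ring. For the measured compounds named here, no measured step between two compounds that differ in only one place exists here, so nothing measured tells how large such a change can be. The expected step in this assay is a step that the limit leaves unreadable from compound 2 to compound 4, none beyond the usual scatter. Compound 4 is thus estimated at 300000 nM, within a range from 100000 nM to 900000 nM, and is expected most likely to return only a limit again.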

Compound 4, half-maximal inhibitory concentration: > 200000 nM
Compound 4 was reported as a limit; the forecaster's own chance of this, stated with the estimate: 85%; the middle value does not contradict the limit.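

Compound 2 and compound 4 both returned only a limit, so no step can be read between them, and phenyl in place of 3,4-dichlorophenyl has no readable size. The compounds shown leave open what would bring a measurable value, because every reading sits at one limit: the limit of > 200000 nM in this assay, at which 4 of the 4 values shown sit.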